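This account rests on a few compounds, and the source may have more. Where it says the series, first, only, none or still open, it means among the compounds named here.

Measured so far, in an ADME assay on Raji cells (Homo sapiens) for cytotoxicity, read by CellTiter-Glo and resazurin assay, with a stated time of 72 h; a higher number here means that more compound is needed for the effect, a lower number that less compound is needed:

compound 1 `CC(C)N(Cc1cccc(OCCCCCC(=O)O)c1)C(=O)c1ccc(-c2ccncc2)cc1`: compound 1 gives a limit, > 26000 nM.
compound 2 `CC(C)COc1cccc(-c2ccc(C(=O)N(Cc3cccc(OCCCCCC(=O)O)c3)C(C)C)cc2)c1`: compound 2 gives a limit, > 26000 nM.
compound 3 `CC(C)N(Cc1cccc(OCCCCCC(=O)O)c1)C(=O)c1ccc(-c2ccoc2)cc1`: compound 3 gives a limit, > 26000 nM.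

Compound 2 stands, like the two other measured compounds, at the limit of this assay; the three values are not numbers and nothing separates them (the limit of > 26000 nM in this assay, at which 3 of the 3 values shown sit).

Compound 4 `COc1cc(OC)cc(-c2ccc(C(=O)N(Cc3cccc(OCCCCCC(=O)O)c3)C(C)C)cc2)c1` is not yet measured. It differs from compound 2 in one place: 3,5-dimethoxyphenyl in place of 3-(isobutoxy)phenyl on an aromatic carbon.

The measured steps that touch compound 2 are a step that the two limits leave unreadable from compound 1 to compound 2 and a step that the two limits leave unreadable from compound 2 to compound 3; both run between two limits, so their size cannot be read. The remaining step, a step that the two limits leave unreadable from compound 1 to compound 3, is unreadable in the same way. The measured series thus gives no direction for the exchange at this position and no sign that any of these changes moves the read-out off the limit.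

Compound 4 is therefore expected to sit at about 35000 nM in this assay, within 15000 nM to 90000 nM, most likely reported as a limit again. The expected step is a step that the limit leaves unreadable from compound 2 to compound 4, that is, none beyond the scatter.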

Compound 4, half-maximal effective concentration: > 26000 nM
Compound 4 was reported as a limit; the forecaster's own chance of this, stated with the estimate: 85%; the middle value does not contradict the limit.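

In this assay compound 4 gives > 26000 nM, a limit and not a number. Its steps to compound 1, compound 2 and compound 3 run between limits and cannot be read: the limit of > 26000 nM in this assay, at which 4 of the 4 values shown sit.

The compounds shown leave open whether any exchange at this position moves the read-out off the limit.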